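A few compounds are considered here, and "the series" means these few. Any claim that something is new, unique, unknown or untested is made for them only; others in the source may bear on it.

In a functional assay on NCI-H460 cells (Homo sapiens) for inhibition, read by sulforhodamine B assay, with a stated time of 48 h, tested at 100 uM (on this read-out lower numbers stand for a stronger effect and higher numbers for a weaker effect at the one concentration tested), compound 1 `COc1cc(Cl)cc(-c2nn(-c3cccc(NC(=O)Nc4ccc(Cl)c(C(F)(F)F)c4)c3)cc2-c2ccncc2)c1` gives -62%, compound 2 `COc1cc(Cl)cc(-c2nn(-c3cccc(NC(=O)Nc4ccc(Cl)c(Cl)c4)c3)cc2-c2ccncc2)c1` gives -8%, and compound 3 `COc1cc(Cl)cc(-c2nn(-c3cccc(NC(=O)Nc4cccc(C(F)(F)F)c4)c3)cc2-c2ccncc2)c1` gives -48%. Compound 3 therefore holds the second highest of the three numbers, with compound 1 as its nearest neighbour and compound 2 as its furthest. The measured steps all concern the outer ring attached to the amide-type nitrogen: a number 54 percentage points higher from compound 1 to compound 2 (beyond the scatter), a number 14 percentage points higher from compound 1 to compound 3 (beyond the scatter) and a number 40 percentage points lower from compound 2 to compound 3 (beyond the scatter).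

Compound 4 `COc1cc(Cl)cc(-c2nn(-c3cccc(NC(=O)c4cccc(C(F)(F)F)c4)c3)cc2-c2ccncc2)c1` is made from compound 3 by a change of a different kind: 3-(trifluoromethyl)phenyl in place of (3-(trifluoromethyl)phenyl)amino on a carbonyl carbon. Among the measured compounds shown here, none of the measured steps touches this part of the molecule, so they give no direct guide to the size or direction of the new step. What stays is that the ring carrying the trifluoromethyl is the same as in compound 3. For the measured compounds named here, with no comparable step in hand, the expectation for compound 4 is loose, and a weakening of the effect, as a number 23 percentage points higher from compound 3 to compound 4 (beyond the scatter), is expected. The estimate for compound 4 in this assay is -25%, expected to lie between -60% and 5%.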

Compound 4, a percentage reported as activity, at one concentration (the size of the read-out at that concentration, not a potency): 30%
For compound 4 the middle estimate is 55 percentage points below the measured one, outside the stated range (above it).
By their numbers in this assay, from the lowest: compound 1; then compound 3; then compound 2; then compound 4.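

In this assay, among the compounds shown here, the link to the outer ring turns out to matter a great deal: with that ring unchanged, replacing (3-(trifluoromethyl)phenyl)amino with 3-(trifluoromethyl)phenyl on the carbonyl carbon gives a number 78 percentage points higher from compound 3 to compound 4 (beyond the scatter), a larger step than any among the earlier compounds. The other two comparisons point the same way, with a number 38 percentage points higher from compound 2 to compound 4 (beyond the scatter) and a number 92 percentage points higher from compound 1 to compound 4 (beyond the scatter), although each also changes the ring substituents, and compound 4 has the weakest effect of the four. Nothing available explains why this change has so large an effect.

Going by these compounds, it remains open whether the nitrogen itself is what matters, which a methylene group or an oxygen atom in its place could test. For the compounds shown here, also open is whether a chloro group on the outer ring of compound 4 would shift its value as it does among the earlier compounds.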